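Swapping a chlorophenyl for a thiophene on a shared core

The source may hold more compounds than are shown below. What is called first, only, known or untested is meant among the compounds shown, and "the series" means these compounds.

Three compounds built on the same fused core were tested in a functional assay on A549 cells (Homo sapiens) for cytotoxicity, read by sulforhodamine B assay, with a stated time of 2 days, tested at 100 uM; on this read-out higher numbers stand for more inhibition at the one concentration tested (going by the name of the read-out) and lower numbers for less inhibition. Compound 1 `CCCc1n[nH]c2c(=O)n(NC(=O)c3ccncc3)c(-c3cccc(OC)c3)nc12` gives 11.2%. Compound 2 `O=C(Nn1c(-c2cccc([N+](=O)[O-])c2)nc2c(-c3ccc(Cl)cc3)n[nH]c2c1=O)c1cccnc1` gives 19.7%, and compound 3 `COc1cccc(-c2nc3c(-c4ccco4)n[nH]c3c(=O)n2NC(=O)c2cccnc2)c1` gives 14.9%. Compound 2 sits at the top of the three readings, but its gaps to compound 3 and to compound 1 both fall within the usual scatter of this measurement, so the three cannot be told apart and no ordering among them is claimed.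

Compound 4 `O=C(Nn1c(-c2cccc([N+](=O)[O-])c2)nc2c(-c3cccs3)n[nH]c2c1=O)c1cccnc1` differs from compound 2 in one place: thiophen-2-yl in place of 4-chlorophenyl on an aromatic carbon. Among the measured compounds shown here, no measured pair in this set shares exactly this kind of exchange, so there is no direct precedent for its effect. Given that the three measured compounds, which vary widely in the groups at this position, all land close together, the step of a number 2.7 percentage points lower from compound 2 to compound 4 (within the scatter) is expected to be small and not beyond the scatter. Compound 4 is therefore estimated at 17%, with a likely range from 5% to 32% in this assay.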

Compound 4, a percentage reported as inhibition, at one concentration (the size of the read-out at that concentration, not a potency): 10.2%
Compound 4: middle estimate off by 6.8 percentage points, on the high side; low and high end bracket the measured number.
By their numbers in this assay, from the lowest: compounds 4, 1, 3 and 2 (each within the scatter of the next).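

Among the compounds shown here, compound 2 and compound 4 form the first pair here that differs in one place, so this aromatic carbon of the five-membered ring can be examined directly. In this assay, placing thiophen-2-yl in place of 4-chlorophenyl gives a number 9.5 percentage points lower from compound 2 to compound 4 (within the scatter), so this exchange shows no effect that can be told from the scatter, even though the entering ring has fewer heavy atoms and adds a hydrogen-bond acceptor. No measurement at hand bears on why the reading behaves this way at this position.

Going by these compounds, whether an amine or a carboxylic acid on this same aromatic carbon would shift the reading beyond the scatter remains open. Also open, on these data alone, is whether thiophen-2-yl and 4-chlorophenyl would still read alike with a different group elsewhere on the shared core.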